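The source may report more compounds than this note shows. Statements on the series, on what has been measured and on what is new or still open speak of the compounds shown alone.

Working notes on the series. The shared core of compound 2 (`COc1ccc(-c2cnc(NC(=O)c3cccnc3)n2C)cc1`) carries an amide; in a toxicity assay on THP-1 cells (Homo sapiens) for inhibition (a higher number here means that more compound is tolerated, a lower number that less compound is tolerated), compound 2 reaches only the limit > 100000 nM, which is a limit of the assay and not a number. Compound 1 (`COc1ccc(-c2cn(C)c(NC(=O)c3ccc(F)cc3)n2)cc1`) likewise gives only a limit, > 50000 nM, in this assay. Compound 3 (`Cc1ccc(C(=O)Nc2ncc(-c3ccccc3)o2)cc1`), on a different core, gives 26000 nM in this assay. Compound 2 therefore stands at the upper edge of what has been seen so far, one of two values that are limits: one at the limit of > 100000 nM in this assay, at which 1 of the 3 values shown sits, one at the limit of > 50000 nM in this assay, at which 1 of the 3 values shown sits. Compound 4 (`COc1ccc(-c2cnc(NC(=O)c3cccc(C)c3)n2C)cc1`) differs from compound 2 in one place: 3-methylphenyl in place of pyridin-3-yl on a carbonyl carbon. Among the compounds with values here, no measured step between two compounds in this assay is available for comparison, so the size of the step to compound 4 can only be guessed. Within the data shown here, the only numeric value, that of compound 3, is below both limits. The step of an at least 2.2-fold lower number from compound 2 to compound 4 (0.34 log units; beyond the scatter) is the expected outcome, a modest downward step that may still end at a limit. Compound 4 is estimated at 45000 nM, between 15000 nM and 120000 nM.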

Compound 4, half-maximal cytotoxic concentration: > 100000 nM
Compound 4 gave a limit, no number; the forecaster's own chance of this, stated with the estimate: 45%; at least 2.2-fold (0.34 log units) between middle value and limit.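

Compound 2 and compound 4 both end at a limit in this assay, so no step can be read between them. The compounds shown leave open whether pyridin-3-yl or 3-methylphenyl on that carbonyl carbon makes any difference to how much compound is tolerated.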